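The source may report more compounds than this note shows. Statements on the series, on what has been measured and on what is new or still open speak of the compounds shown alone.

Compound 1, `CC(C)CCCN(C)Cc1ccc(C2=CCCN(C)C2)cc1`, and compound 2, `CC(C)CCN(C)Cc1ccc(C2CCCN(C)C2)cc1`, have both been tested in an ADME assay on HL-60 cells (Homo sapiens) for cytotoxicity, read by MTT assay, with a stated time of 24 h; a lower number here means a stronger inhibitor, a higher number a weaker inhibitor. Compound 1 gives > 50000 nM, which is a limit of the assay and not a number. Compound 2 gives > 50000 nM, which is also a limit and not a number. Compound 2 therefore has no exact position on the scale, and the measured data amount to the limit of > 50000 nM in this assay, at which 2 of the 2 values shown sit.

The next compound is compound 3, `CC(C)CCCN(C)Cc1ccc(C2CCCN(C)C2)cc1`. It differs from compound 2 in one place: isobutyl in place of isopropyl on a saturated chain carbon, two bonds along the chain from an amine nitrogen. In words, isobutyl stands in place of isopropyl on a saturated chain carbon, two bonds along the chain from an amine nitrogen.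

For the measured compounds named here, no measured pair shows what a change of this kind does in this assay, so the expectation rests on little. With compound 2 reported as > 50000 nM, no step beyond the usual scatter is expected, in either direction. The expected change is a number no higher from compound 2 to compound 3 (the limit leaves the size open). The most likely result is another limit rather than a number. For compound 3, the estimated value is 50000 nM, with an expected range from 25000 nM to 90000 nM.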

Compound 3, half-maximal inhibitory concentration: > 50000 nM
Compound 3 was reported as a limit; the forecaster's own chance of this, stated with the estimate: 85%; the middle value sits exactly at the limit.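

No step to compound 3 from compound 1 or compound 2 can be read in this assay, because all the values stop at one limit of the assay, which is not a number: the limit of > 50000 nM in this assay, at which 3 of the 3 values shown sit.

The compounds shown leave open what exact value each one has, and whether any change to the shared core would give a measurable number in this assay.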